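From Dimethylamino to Hydroxy: One Change, One Expectation

The compounds below may be only part of what the source reports. "The series", "measured", "known", "first", "only" and "open" are said of these compounds alone.

Two compounds share one core and differ only in the group carried on the aromatic nitrogen. Compound 1 `CC(C)c1cccc(C(C)C)c1NC(=O)Nc1nc2ccccc2n1-c1ccc(Cl)cc1` carries a 4-chlorophenyl there, and in an assay on isolated protein for displacement of a labelled ligand from acyl-CoA:cholesterol acyltransferase (Oryctolagus cuniculus) (a higher number here means a weaker inhibitor, a lower number a stronger inhibitor), compound 1 gives 280 nM. Compound 2 `CC(C)c1cccc(C(C)C)c1NC(=O)Nc1nc2ccccc2n1-c1ccccc1N(C)C` carries a 2-(dimethylamino)phenyl instead, and in this assay compound 2 gives 41 nM. Among the measured compounds shown here, the single measured step, a 6.8-fold lower number from compound 1 to compound 2 (0.83 log units; beyond the scatter), shows that this swap brought a lower number. For the measured compounds named here, on the numbers in hand, compound 2 therefore stands lowest of the two, with compound 1 as its only neighbour.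

Compound 3 `CC(C)c1cccc(C(C)C)c1NC(=O)Nc1nc2ccccc2n1-c1ccccc1O` takes the next step: hydroxy in place of dimethylamino on an aromatic carbon. Going by the values given here, no measured step bears directly on this change; the only known step, a 6.8-fold lower number from compound 1 to compound 2 (0.83 log units; beyond the scatter), concerns a different pair of groups at the same place, so it shows only that this position tolerates variation. With nothing to anchor a direction, compound 3 is expected to stay near compound 2, within a wide range. Compound 3 is estimated at 60 nM in this assay, between 20 nM and 200 nM, a step of a 1.5-fold higher number from compound 2 to compound 3 (0.17 log units; within the scatter) that is expected to sit within the scatter.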

Compound 3, half-maximal inhibitory concentration: 200 nM
Beside the measured number, compound 3's estimate is 3.3-fold (0.52 log units) below it, and the stated range covers the measured number.
By their numbers in this assay, from the lowest: compound 2; then compounds 3 and 1 (each within the scatter of the next).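

Replacing dimethylamino with hydroxy on this aromatic carbon matters: in this assay the change gives a 4.9-fold higher number from compound 2 to compound 3 (0.69 log units; beyond the scatter), so the low number of compound 2 depends on which group sits there and is not secured by just any small group at this place. Among the compounds shown here, the comparison with the first compound of the series points the same way, since a 1.4-fold lower number from compound 1 to compound 3 (0.15 log units; within the scatter) leaves the 2-hydroxyphenyl and 4-chlorophenyl groups on the aromatic nitrogen indistinguishable in this measurement, and of the three groups tested on that nitrogen, only 2-(dimethylamino)phenyl stands clearly apart. No available information explains why the two groups on this aromatic carbon give such different numbers.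

The compounds shown leave open which part of dimethylamino matters, as a simple amino group, a methylamino group, or a longer diethylamino group at the same aromatic carbon would each test a different part of that question. They also leave open how a methoxy group, which keeps the oxygen of hydroxy and adds one carbon, would compare with compound 2 and compound 3.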